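Swapping tert-butyl for tert-butoxy on the carbonyl carbon

The source may report more compounds than this note shows. Statements on the series, on what has been measured and on what is new or still open speak of the compounds shown alone.

Values in a functional assay on HepG2 cells (Homo sapiens) for inhibition, read by scintillation counting, with a stated time of 2 h; a higher number here means a weaker inhibitor, a lower number a stronger inhibitor:
- compound 1 `CCNC(=O)Nc1sc2ccccc2c1C(=O)N1CCN(C2CCN(C(=O)C3CCCC3)CC2)CC1`: 309 nM
- compound 2 `CCNC(=O)Nc1sc2ccccc2c1C(=O)N1CCN(C2CCN(C(=O)C3CCCCC3)CC2)CC1`: 146 nM
- compound 3 `CCNC(=O)Nc1sc2ccccc2c1C(=O)N1CCN(C2CCN(C(=O)C(C)(C)C)CC2)CC1`: 450 nM

These three compounds share one core and differ only in the group on a carbonyl carbon. In this assay, compound 3 gives 450 nM. Two steps place it: a 1.5-fold higher number from compound 1 to compound 3 (0.16 log units; within the scatter), and a 3.1-fold higher number from compound 2 to compound 3 (0.49 log units; beyond the scatter).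

Compound 4 `CCNC(=O)Nc1sc2ccccc2c1C(=O)N1CCN(C2CCN(C(=O)OC(C)(C)C)CC2)CC1` carries tert-butoxy in place of tert-butyl on a carbonyl carbon whose other neighbour is an amide-type nitrogen in a ring: tert-butoxy in place of tert-butyl on a carbonyl carbon. The measured steps change the group at this same place, so they are the best guide available. The step of a 2.1-fold lower number from compound 1 to compound 2 (0.33 log units; beyond the scatter) and the step of a 3.1-fold higher number from compound 2 to compound 3 (0.49 log units; beyond the scatter) are both modest. Within the data shown here, none of them brings in an oxygen, however, so they offer no direct precedent for this change, and the direction stays open.

No step beyond the scatter is expected, and the estimated change is a 1.1-fold lower number from compound 3 to compound 4 (0.05 log units; within the scatter). The expected value for compound 4 is 400 nM, with a likely range from 150 nM to 1000 nM.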

Compound 4, half-maximal inhibitory concentration: 79 nM
For compound 4 the middle estimate is 5.1-fold (0.70 log units) above the measured one, and the stated range ends above it.
By their numbers in this assay, from the lowest: compounds 4 and 2 (each within the scatter of the next); then compounds 1 and 3 (each within the scatter of the next).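

In this assay, adding a single oxygen to the group on this carbonyl carbon, turning (tert-butyl)carbonyl into tert-butoxycarbonyl, gives a 5.7-fold lower number from compound 3 to compound 4 (0.76 log units; beyond the scatter). A change of one heavy atom at this place is therefore enough to move the number beyond the scatter, something the earlier all-carbon groups gave no way of seeing. The open-chain tert-butoxy group also keeps pace with the cyclohexyl ring, with a 1.8-fold lower number from compound 2 to compound 4 (0.27 log units; within the scatter), and it separates clearly from the cyclopentyl ring, with a 3.9-fold lower number from compound 1 to compound 4 (0.59 log units; beyond the scatter).

Nothing available explains why the oxygen has this effect. The compounds shown also leave open whether a smaller methoxy group, or a tert-butylamino group with nitrogen in the oxygen's place, would give a similar result.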